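Methyl for Hydrogen on an Aromatic Oxygen: Expected Effect

The compounds below may be only part of what the source reports. "The series", "measured", "known", "first", "only" and "open" are said of these compounds alone.

Measured compounds in a functional assay on HL-60 cells (Homo sapiens) for antiproliferative activity; a higher number here means a weaker inhibitor, a lower number a stronger inhibitor: compound 1 `COc1cc(OC)cc(-c2cccc(-c3ccc(O)cc3)c2)c1` gives 4800 nM; compound 2 `COc1ccc(-c2cccc(-c3cc(OC)cc(OC)c3)c2)cc1` gives 50000 nM; compound 3 `COc1cc(OC)cc(-c2ccccc2-c2ccc(O)cc2)c1` gives 5000 nM.

Compound 1 and compound 3 are built from the same atoms joined differently; the difference between the two cores is not broken down here. Their numbers in this assay lie within the usual scatter of each other. Between compound 1 and compound 2 the change is methyl in place of hydrogen on an oxygen on an aromatic ring, and it produced a 10-fold higher number from compound 1 to compound 2 (1.02 log units; beyond the scatter). Compound 4 `COc1ccc(-c2ccccc2-c2cc(OC)cc(OC)c2)cc1` has not been measured; it differs from compound 3 by methyl in place of hydrogen on an oxygen on an aromatic ring, the same change made at the same place. Because a 10-fold higher number from compound 1 to compound 2 (1.02 log units; beyond the scatter) lay beyond the scatter, compound 4 is expected to weaken by a 10-fold higher number from compound 3 to compound 4 (1.00 log units; beyond the scatter) in this assay. Compound 4 is therefore estimated at 50000 nM, with a likely range from 15000 nM to 150000 nM.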

Compound 4, half-maximal inhibitory concentration: 7000 nM
The estimate for compound 4 lay 7.1-fold (0.85 log units) above the measured number, and the stated range ends above it.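

In this assay, methyl in place of hydrogen on an oxygen on an aromatic ring gave a 1.4-fold higher number from compound 3 to compound 4 (0.15 log units; within the scatter) on the core of compound 3, so no change in the number can be claimed there. The same change on the two cores did not give a step of the same size: the same change on two cores in this assay, a 10-fold higher number (1.02 log units; beyond the scatter) from compound 1 to compound 2 and a 1.4-fold higher number (0.15 log units; within the scatter) from compound 3 to compound 4, 7.4-fold (0.87 log units) apart, beyond the scatter of two such steps. This shows that a step read on the core of compound 1 did not carry over to the core of compound 3, but two pairs do not show which difference between the cores accounts for this, or what the change would do on any further core.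

The compounds shown leave open how a longer chain on that oxygen would behave on either core. They also leave open whether an amine in place of the hydroxy group would separate the two cores in the same way.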